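The source may report more compounds than this note shows. Statements on the series, on what has been measured and on what is new or still open speak of the compounds shown alone.

Measured compounds in this series:
compound 1 `CCCc1ccc(/C=C/C(=O)Nc2ccc3nc(CCC)cc(N)c3c2)cc1` — 3600 nM
compound 2 `CCCc1cc(N)c2cc(NC(=O)/C=C/c3ccc(C(C)(C)C)cc3)ccc2n1` — 910 nM
compound 3 `CCCc1cc(N)c2cc(NC(=O)/C=C/c3ccc(F)cc3)ccc2n1` — 200 nM

In a functional assay on HEK293 cells for activation of melanin-concentrating hormone receptor 1 (Homo sapiens), read by inositol phosphate accumulation (a lower number here means that less compound is needed, a higher number that more compound is needed for the effect), compound 3 gives the lowest number of the three: the nearest is a 4.6-fold lower number from compound 2 to compound 3 (0.66 log units; beyond the scatter), the furthest an 18-fold lower number from compound 1 to compound 3 (1.26 log units; beyond the scatter). Compound 4 `CCCc1cc(N)c2cc(NC(=O)/C=C/c3ccc(Br)cc3)ccc2n1` is not yet measured. It differs from compound 3 by bromo in place of fluoro on an aromatic carbon. For the measured compounds named here, no measured step exchanges one halogen for another; the steps that bear on this position all replaced an alkyl group with fluoro and gave lower numbers, so compound 3 may already sit near the low end of what this position allows. A small shift to a higher number is expected for compound 4, a 1.8-fold higher number from compound 3 to compound 4 (0.24 log units; within the scatter), within or just beyond the scatter. Compound 4 is estimated at 350 nM, range 120 nM to 1000 nM.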

Compound 4, half-maximal effective concentration: 93 nM
Compound 4: middle estimate off by 3.8-fold (0.58 log units), on the high side; measured number below the stated range.
By their numbers in this assay, from the lowest: compound 4; then compound 3; then compound 2; then compound 1.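

In this assay, for the compounds shown here, this is the first exchange of one halogen for another at this position, and it gives a 2.2-fold lower number from compound 3 to compound 4 (0.33 log units; beyond the scatter), so fluoro does not mark the low end of what the position allows. Against the alkyl groups, bromo gives a 9.8-fold lower number from compound 2 to compound 4 (0.99 log units; beyond the scatter) and a 39-fold lower number from compound 1 to compound 4 (1.59 log units; beyond the scatter), both larger steps than fluoro gave from the same compounds. No available data account for the difference between bromo and fluoro.

With only two halogens, no order among halogens is established. Chloro, iodo, methoxy and nitrile at this position remain open.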